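The source may report more compounds than this note shows. Statements on the series, on what has been measured and on what is new or still open speak of the compounds shown alone.

Measured in a functional assay for inhibition, with Homo sapiens as the target; on this read-out lower numbers stand for tighter binding and higher numbers for weaker binding:
- compound 1 `O=C(O)CC/C=C\CC1COC(c2ccc(Cl)cc2Cl)OC1c1cccnc1`: 891 nM
- compound 2 `CC(C)(Oc1ccccc1)C1OCC(C/C=C\CCC(=O)O)C(c2cccnc2)O1`: 75.9 nM

Of these two, compound 2 has the lower number, 75.9 nM, so it binds more tightly. The next compound, compound 3 `CC(C)(Oc1ccccc1F)C1OCC(C/C=C\CCC(=O)O)C(c2cccnc2)O1`, keeps all of compound 2 except for one small change: fluoro in place of hydrogen on an aromatic carbon. This puts fluoro in place of hydrogen on an aromatic carbon, turning phenoxy into 2-fluorophenoxy.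

Within the data shown here, only one measured step is available as a guide. That step, a 12-fold lower number from compound 1 to compound 2 (1.07 log units; beyond the scatter), is large, but it exchanges one whole group for another on a saturated ring carbon. Among the measured compounds shown here, it therefore says little about a single fluoro on the phenoxy ring, and no measured pair isolates that kind of change. For the measured compounds named here, with so small an edit and no direct precedent, a modest shift is the reasonable expectation, leaning slightly towards tighter binding with low confidence. The expected step is a 1.7-fold lower number from compound 2 to compound 3 (0.23 log units; within the scatter), which would not lie beyond the scatter. For compound 3 the estimated value in this assay is 45 nM, with an expected range from 15 nM to 130 nM.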

Compound 3, dissociation constant: 166 nM
Compound 3: middle estimate off by 3.7-fold (0.57 log units), on the low side; the whole stated range lies below it.
By their numbers in this assay, from the lowest: compound 2; then compound 3; then compound 1.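

Among the compounds shown, this is the only step that touches the phenoxy ring itself: in this assay, turning phenoxy into 2-fluorophenoxy gives a 2.2-fold higher number from compound 2 to compound 3 (0.34 log units; beyond the scatter), a modest step that lies beyond the scatter. A single fluoro, just one heavy atom on an aromatic carbon ortho to a large group, is therefore enough to shift the number towards weaker binding, so this position does respond to what is placed on it. Nothing measured here gives a reason for that shift.

From the compounds shown here alone, only hydrogen and fluoro have been seen at this carbon, so it remains open how a chloro, a methyl or a methoxy group in the same place would compare, and whether any group here could move the number towards tighter binding. Going by these compounds, with one fluoro compound in hand, it is also open whether the upward shift belongs to this particular carbon or would appear with fluoro on the other carbons of the phenoxy ring.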